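The source may report more compounds than this note shows. Statements on the series, on what has been measured and on what is new or still open speak of the compounds shown alone.

Measured in an ADME assay on the whole organism (Macaca fascicularis) for pharmacokinetics, at a dose of 1 mg/kg by the oral route; a higher number here means more compound in the circulation at the dose given, a lower number less compound in the circulation:
Compound 1 `Cc1sc(N(CC2CC2)[C@H](C)c2ccc(-c3cc(Cl)ccc3-c3nc(=O)o[nH]3)cc2)nc1C(=O)NS(C)(=O)=O` gives 726 ng.h/mL.
Compound 2 `CCS(=O)(=O)NC(=O)c1nc(N(CC2CC2)[C@H](C)c2ccc(-c3cc(Cl)ccc3-c3nc(=O)o[nH]3)cc2)sc1C` gives 2170 ng.h/mL.
Compound 3 `Cc1sc(N(CC2CC2)[C@H](C)c2ccc(-c3cc(Cl)ccc3-c3nc(=O)o[nH]3)cc2)nc1C(=O)NS(=O)(=O)C1CC1` gives 3740 ng.h/mL.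

Compound 3 has the highest of the three numbers in this assay. Its gap to compound 2 is within the scatter, so these two cannot be ranked against each other, while its gap to compound 1 is beyond the scatter. Compound 4 `Cc1sc(N(CC2CC2)[C@H](C)c2ccc(-c3cc(Cl)ccc3-c3nc(=O)o[nH]3)cc2)nc1C(=O)NS(=O)(=O)C1CCCC1` differs from compound 3 in one place: cyclopentyl in place of cyclopropyl on a sulfonyl sulfur. Going by the values given here, three measured steps bear on this position. a 3.0-fold higher number from compound 1 to compound 2 (0.48 log units; beyond the scatter) and a 5.2-fold higher number from compound 1 to compound 3 (0.71 log units; beyond the scatter) both went with more compound in the circulation when the methyl on the sulfonyl sulfur was exchanged for an ethyl or a cyclopropyl. a 1.7-fold higher number from compound 2 to compound 3 (0.24 log units; within the scatter), between ethyl and cyclopropyl, stayed within the scatter. No measured compound carries a cyclopentyl at this position, so the move from a three-membered to a five-membered ring is untested, and the flat step between compound 2 and compound 3 gives no reason to expect a further rise. Compound 4 is therefore expected to show a step of a 1.1-fold lower number from compound 3 to compound 4 (0.03 log units; within the scatter), likely within the scatter. Compound 4 is estimated at 3500 ng.h/mL, in the range 1500 ng.h/mL to 8000 ng.h/mL.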

Compound 4, area under the concentration-time curve: 1730 ng.h/mL
Compound 4: middle estimate off by 2.0-fold (0.31 log units), on the high side, and the stated range covers the measured number.
By their numbers in this assay, from the lowest: compound 1; then compounds 4, 2 and 3 (each within the scatter of the next, the first and the last beyond it).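

In this assay, this sulfonyl sulfur now shows a limit to the earlier gain: the larger ring gives a 2.2-fold lower number from compound 3 to compound 4 (0.33 log units; beyond the scatter), so adding carbon here does not simply keep raising the number, and compound 4 stands against any such trend. Cyclopentyl still keeps part of the gain over methyl, with a 2.4-fold higher number from compound 1 to compound 4 (0.38 log units; beyond the scatter), while against the open-chain ethyl it gives a 1.3-fold lower number from compound 2 to compound 4 (0.10 log units; within the scatter), a gap too small to rank the two groups. Nothing shown accounts for the difference between the five-membered and three-membered rings.

Still open, going by these compounds, is how the number changes with ring size at this sulfur, which a cyclobutyl would help to show, and whether a branched or longer chain such as isopropyl or propyl would behave like ethyl or like cyclopentyl. On these data alone, it is also open whether a group carrying an amine or a hydroxyl would keep the number of compound 3, and these whole-animal numbers alone cannot tell whether uptake or removal from the body changed.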